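Pyridin-3-yl in Place of 3-Methylphenyl on the Amide Carbonyl

This account rests on a few compounds, and the source may have more. Where it says the series, first, only, none or still open, it means among the compounds named here.

Compound 1, `O=C(Nc1c(C(O)(C(F)(F)F)C(F)(F)F)ccc2ccccc12)C1CC1`: 126 nM
Compound 2, `COCC(=O)Nc1c(C(O)(C(F)(F)F)C(F)(F)F)ccc2ccccc12`: 204 nM
Compound 3, `Cc1cccc(C(=O)Nc2c(C(O)(C(F)(F)F)C(F)(F)F)ccc3ccccc23)c1`: 52.5 nM

In a functional assay (Sus scrofa) with sulfonylurea receptors; K-ATP channels (Homo sapiens) as the target (a lower number here means that less compound is needed, a higher number that more compound is needed for the effect), compound 3 gives the lowest number of the three measured compounds, as the steps of a 2.4-fold lower number from compound 1 to compound 3 (0.38 log units; beyond the scatter) and a 3.9-fold lower number from compound 2 to compound 3 (0.59 log units; beyond the scatter) show. Compound 4, `O=C(Nc1c(C(O)(C(F)(F)F)C(F)(F)F)ccc2ccccc12)c1cccnc1`, differs from compound 3 in one place: pyridin-3-yl in place of 3-methylphenyl on a carbonyl carbon. Going by the values given here, no measured step exchanges one aromatic ring for another; the two steps leading to compound 3 both replace a small non-aromatic group with 3-methylphenyl, and the step of a 1.6-fold higher number from compound 1 to compound 2 (0.21 log units; within the scatter) lies within the scatter. These steps therefore bear only loosely on the change at hand. Compound 4 is expected to stay close to compound 3, with a step of a 1.5-fold higher number from compound 3 to compound 4 (0.18 log units; within the scatter) in this assay, and the estimate for compound 4 is 80 nM, ranging from 35 nM to 180 nM.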

Compound 4, half-maximal effective concentration: 617 nM
Estimate against measurement, compound 4: 7.7-fold (0.89 log units) below; the whole stated range lies below it.
By their numbers in this assay, from the lowest: compound 3; then compounds 1 and 2 (each within the scatter of the next); then compound 4.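

In this assay, exchanging one aromatic ring for another on the carbonyl carbon proved far from neutral: pyridin-3-yl in place of 3-methylphenyl gives a 12-fold higher number from compound 3 to compound 4 (1.07 log units; beyond the scatter) and is the largest step seen at this position. The steps of a 4.9-fold higher number from compound 1 to compound 4 (0.69 log units; beyond the scatter) and a 3.0-fold higher number from compound 2 to compound 4 (0.48 log units; beyond the scatter) show that an aromatic ring here does not by itself give a low number. No measured evidence accounts for this result.

What phenyl without the methyl or pyridin-4-yl would give on this carbonyl carbon remains open, so the compounds shown cannot separate the loss of the methyl from the entry of the ring nitrogen.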